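This account rests on a few compounds, and the source may have more. Where it says the series, first, only, none or still open, it means among the compounds named here.

Of the compounds shown here, three sharing one core have been measured in a functional assay on MCF7 cells (Homo sapiens) for inhibition, read by CCK-8 assay, with a stated time of 48 h; on this read-out lower numbers stand for stronger inhibition and higher numbers for weaker inhibition. Compound 1 `COc1cc(-c2ccnc3c(-c4ccc(C)cc4)cnn23)cc(OC)c1OC` gives > 10000 nM, which is a limit of the assay rather than a number. Compound 3 `Cc1ccc(-c2cc3nccc(-c4ccc(F)cc4)n3n2)cc1` likewise gives > 10000 nM, again a limit. Compound 2 `COc1cc(-c2ccnc3cc(-c4ccc(C(C)(C)C)cc4)nn23)cc(OC)c1OC` also sits at a limit, > 10000 nM. Compound 2 therefore stands exactly where every value shown stands: the limit of > 10000 nM in this assay, at which 3 of the 3 values shown sit. Compound 4 `COc1cc(-c2ccnc3cc(-c4cn(C)c5ccccc45)nn23)cc(OC)c1OC` has not yet been measured. It differs from compound 2 in one place: 1-methyl-1H-indol-3-yl in place of 4-(tert-butyl)phenyl on an aromatic carbon. Among the compounds with values here, no measured pair differing in a single place exists here, so the size of such a step cannot be read from other compounds. With every measured value a limit, compound 4 is expected to remain weak, and the expected step, an at least 1.2-fold lower number from compound 2 to compound 4 (0.09 log units; that floor lies within the scatter), is small. Compound 4 is estimated at about 8000 nM, between 2000 nM and 30000 nM, most likely reported again only as a limit.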

Compound 4, half-maximal inhibitory concentration: 95 nM
The estimate for compound 4 lay 84-fold (1.93 log units) above the measured number, outside the stated range (below it).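

In this assay, this position on the shared core proves able to carry strong activity: 1-methyl-1H-indol-3-yl in place of 4-(tert-butyl)phenyl gives an at least 100-fold lower number from compound 2 to compound 4 (2.02 log units; beyond the scatter). Both groups count the same heavy atoms, so that count does not separate them; they differ in their rings and in the one hydrogen-bond acceptor that enters. The value of compound 2 is a limit of the assay, so this step is a floor, not an exact size: the limit of > 10000 nM in this assay, at which 3 of the 4 values shown sit.

On these data alone, it remains open whether the methyl on the indole is needed. As far as these compounds go, how a plain 1H-indol-3-yl, or a phenyl carrying an amine, would behave here is also open.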